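Hydroxy for methoxy on the aryl group flanking the ring nitrogen

The compounds below may be only part of what the source reports. "The series", "measured", "known", "first", "only" and "open" are said of these compounds alone.

Of the compounds shown here, three of the shared core have been measured in a functional assay on T47D cells (Homo sapiens) for cytotoxicity, read by CCK-8 assay and cell counting, with a stated time of 72 h; on this read-out lower numbers stand for stronger inhibition and higher numbers for weaker inhibition. Compound 1 `COc1ccc(-c2cc3ccccc3c(-c3cccc(O)c3)n2)cc1` gives 580 nM; compound 2 `COc1ccc(-c2cc3ccccc3c(-c3cccc(OC)c3)n2)cc1` gives 860 nM; compound 3 `COc1cc(OC)cc(-c2cc3ccccc3c(-c3cccc(OC)c3)n2)c1` gives 1120 nM. Compound 3 thus stands at the highest number of the three, but its gaps to compound 2 and to compound 1 are both within the scatter, so no order among them can be read.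

Compound 4 `COc1cc(OC)cc(-c2cc3ccccc3c(-c3ccc(O)cc3)n2)c1` differs from compound 3 by 4-hydroxyphenyl in place of 3-methoxyphenyl on an aromatic carbon. Within the data shown here, the only measured step that bears on this change is the one between compound 1 and compound 2, a 1.5-fold higher number from compound 1 to compound 2 (0.17 log units; within the scatter), which exchanges hydrogen and methyl on the oxygen of that same aryl group and stays within the scatter. Among the measured compounds shown here, no measured pair shows the oxygen moved from one position of the ring to another, so that part of the change is untested here. On this basis the step of a 1.3-fold lower number from compound 3 to compound 4 (0.12 log units; within the scatter) is expected to stay small, and compound 4 is estimated at 850 nM, with a range from 350 nM to 2200 nM.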

Compound 4, half-maximal inhibitory concentration: 780 nM
For compound 4 the middle estimate is 1.1-fold (0.04 log units) above the measured one, and the stated range covers the measured number.
By their numbers in this assay, from the lowest: compounds 1, 4, 2 and 3 (each within the scatter of the next).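

At the aryl group next to the ring nitrogen, 4-hydroxyphenyl in place of 3-methoxyphenyl gives a 1.4-fold lower number from compound 3 to compound 4 (0.16 log units; within the scatter) in this assay, so this exchange leaves the number within the scatter. Unlike the earlier step on the same aryl group, this one alters the place of the oxygen on that ring as well as the group on the oxygen, and even this double change produces no readable shift at this position. No supporting measurement is available to explain the result.

The step cannot be divided between the move of the oxygen and the loss of its methyl, and the series has yet to show any change at this position that clearly goes beyond the scatter. From the compounds shown here alone, how an amine, a carboxylic acid or a longer chain on the oxygen would behave here remains open.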